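Swapping the aryl amine for cyclohexyl on the naphthoquinone series

The compounds below may be only part of what the source reports. "The series", "measured", "known", "first", "only" and "open" are said of these compounds alone.

Of the compounds shown here, three sharing one core have been measured in a functional assay on HeLa cells (Homo sapiens) for cytotoxicity, read by MTT assay, with a stated time of 48 h; on this read-out higher numbers stand for weaker inhibition and lower numbers for stronger inhibition. Compound 1 `Cc1ccc(S(=O)(=O)/N=C(/CCNC2=CC(=O)c3ccccc3C2=O)Nc2cccc(C)c2)cc1` gives 9060 nM. Compound 2 `COc1ccc(N/C(CCNC2=CC(=O)c3ccccc3C2=O)=N\S(=O)(=O)c2ccc(C)cc2)cc1OC` gives 14500 nM, the highest number of the three; its nearest neighbour is compound 1, and the step of a 1.6-fold higher number from compound 1 to compound 2 (0.20 log units; within the scatter) stays within the scatter. Compound 3 `COc1cc(N/C(CCNC2=CC(=O)c3ccccc3C2=O)=N\S(=O)(=O)c2ccc(C)cc2)cc(OC)c1OC` gives 3390 nM, and the step of a 4.3-fold lower number from compound 2 to compound 3 (0.63 log units; beyond the scatter) is a modest one beyond the scatter, as is a 2.7-fold lower number from compound 1 to compound 3 (0.43 log units; beyond the scatter).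

The next compound, compound 4 `Cc1ccc(S(=O)(=O)/N=C(/CCNC2=CC(=O)c3ccccc3C2=O)NC2CCCCC2)cc1`, differs from compound 2 in one place: cyclohexyl in place of 3,4-dimethoxyphenyl on an amine nitrogen. Going by the values given here, none of the measured steps covers this kind of change; all three move from one substituted phenyl ring to another, and the only one that left the number essentially unmoved, a 1.6-fold higher number from compound 1 to compound 2 (0.20 log units; within the scatter), is also the only one that did not add a methoxy group. The replacement of an aromatic ring by a saturated one has no precedent among these compounds, so the expectation rests on the general spread of the series rather than on any direct analogue. The author therefore expects no step beyond the scatter, a 1.1-fold lower number from compound 2 to compound 4 (0.05 log units; within the scatter), and estimates for compound 4 a value of 13000 nM, within the range 4000 nM to 45000 nM.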

Compound 4, half-maximal inhibitory concentration: 9770 nM
The estimate for compound 4 lay 1.3-fold (0.12 log units) above the measured number, within the range that was stated.
By their numbers in this assay, from the lowest: compound 3; then compounds 1, 4 and 2 (each within the scatter of the next).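

At this amine nitrogen, a saturated cyclohexyl ring takes the place of a substituted phenyl ring with no change beyond the scatter in this assay, as shown by a 1.5-fold lower number from compound 2 to compound 4 (0.17 log units; within the scatter) and by a 1.1-fold higher number from compound 1 to compound 4 (0.03 log units; within the scatter). The 3,4,5-trimethoxyphenyl group is the one aryl group shown that separates from cyclohexyl, with a 2.9-fold higher number from compound 3 to compound 4 (0.46 log units; beyond the scatter), so among these four compounds an aromatic ring at this position goes with a clearly lower number only when it carries that particular substitution. Nothing on hand accounts for any of these results.

From the compounds shown here alone, it remains open whether the match between cyclohexyl and the two aryl groups extends to other non-aromatic groups on this nitrogen, such as cyclopentyl, a piperidine ring or an open hexyl chain. Also open, going by these compounds, is whether the lower number of compound 3 depends on the methoxy groups themselves, a question that a 3,4,5-trimethylphenyl or 3,4,5-trifluorophenyl group at the same place would help to settle.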